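This account rests on a few compounds, and the source may have more. Where it says the series, first, only, none or still open, it means among the compounds named here.

In an ADME assay on L02 cells (Homo sapiens) for inhibition, read by CCK-8 assay, with a stated time of 48 h (on this read-out lower numbers stand for stronger inhibition of growth and higher numbers for weaker inhibition of growth), compound 2 (`CN1CCN(c2ccc(Nc3ncc(Cl)c(NCc4ccc(C(F)(F)F)cc4)n3)nc2)CC1`) gives 26200 nM as its result, and compound 3 (`CN1CCN(c2ccc(Nc3ncc(Cl)c(NCc4ccc(F)cc4)n3)nc2)CC1`) gives 39700 nM as its result. These two sit together on the scale, with a 1.5-fold higher number from compound 2 to compound 3 (0.18 log units; within the scatter) when fluoro takes the place of trifluoromethyl on an aromatic carbon. Compound 3 therefore stands level with compound 2. Compound 1 (`Cc1ccccc1Nc1nc(NCc2ccccc2)ncc1Cl`) gives > 100000 nM as its result, and this is a limit of the assay, not a number.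

Compound 4 (`Cc1ccc(Nc2nc(Nc3ccc(N4CCN(C)CC4)cn3)ncc2Cl)cc1`) has not yet been measured. Counted out, its difference reads 4-methylphenyl in place of 4-fluorobenzyl on a nitrogen on an aromatic ring and in words 4-methylphenyl stands in place of 4-fluorobenzyl on a nitrogen on an aromatic ring. The same difference can be read as (4-fluorobenzyl)amino giving way to (4-methylphenyl)amino.

For the measured compounds named here, no measured step changes this place. Going by the values given here, the only step available, a 1.5-fold higher number from compound 2 to compound 3 (0.18 log units; within the scatter) in size, swaps a different group, so it is a weak guide. With nothing pointing either way, compound 4 is expected to stay close to compound 3 at 39700 nM on this scale. The expected 1.3-fold lower number from compound 3 to compound 4 (0.12 log units; within the scatter) is not a step beyond the scatter in either direction. In this assay compound 4 is estimated at 30000 nM with an expected range from 10000 nM to 80000 nM for its value.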

Compound 4, concentration for 50% growth inhibition: 13900 nM
For compound 4 the middle estimate is 2.2-fold (0.33 log units) above the measured one; measured number inside the range.
By their numbers in this assay, from the lowest: compounds 4, 2 and 3 (each within the scatter of the next, the first and the last beyond it). At a limit, above all of these: compound 1.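

Compounds 2 and 3 changed only the group carried on the benzyl ring, and that swap stayed within the scatter. For the compounds shown here, compound 4 is the first to change what sits on the nitrogen on an aromatic ring, with 4-methylphenyl in place of 4-fluorobenzyl, and in this assay this gives a 2.9-fold lower number from compound 3 to compound 4 (0.46 log units; beyond the scatter) as the first step here that lies beyond the scatter, in the direction of stronger inhibition of growth. Set against the trifluoromethyl compound, the change gives a 1.9-fold lower number from compound 2 to compound 4 (0.28 log units; within the scatter) and stays within the scatter, so the position responds clearly only in the comparison with compound 3, and compound 4 cannot be told apart from compound 2.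

The step from compound 3 changes two things at once, the benzyl link and the fluoro on the ring, so a 4-fluorophenyl or a 4-methylbenzyl group would be needed to show which of them carries the shift. Nothing measured here accounts for the shift in cause, and none of the evidence shown bears on it.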